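Swapping a hydroxy for a methyl on an imidazolyl tetralin core

The compounds below may be only part of what the source reports. "The series", "measured", "known", "first", "only" and "open" are said of these compounds alone.

Of the compounds shown here, two sharing one core have been measured in an assay on isolated protein for binding affinity to Alpha-1A adrenergic receptor (Rattus norvegicus), read by radioligand binding; on this read-out lower numbers stand for stronger inhibition and higher numbers for weaker inhibition. Compound 1, `CCCS(=O)(=O)Nc1cccc2c1CCCC2c1c[nH]cn1`, carries a propanesulfonamido group and gives 1700 nM. Compound 2, `CS(=O)(=O)Nc1ccc(O)c2c1CCCC2c1c[nH]cn1`, carries a methanesulfonamido group together with a hydroxy on the aromatic ring, and in this assay compound 2 gives 708 nM. Of the two numbers, that of compound 2 is the lower one, and the gap to compound 1 lies beyond the usual scatter of the method.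

Compound 3, `Cc1ccc(NS(C)(=O)=O)c2c1C(c1c[nH]cn1)CCC2`, differs from compound 2 in a single place: methyl in place of hydroxy on an aromatic carbon. The group that leaves is both a hydrogen-bond donor and a hydrogen-bond acceptor, and the methyl that enters is neither. Among the measured pair there is no change of exactly this kind, so no measured step can guide the size of the effect. In this assay a shift of modest size toward a weaker number is expected, at the edge of the scatter rather than far beyond it, giving an estimated step of a 1.7-fold higher number from compound 2 to compound 3 (0.23 log units; within the scatter). For compound 3 the expected inhibition constant is 1200 nM, within a range from 400 nM to 3500 nM.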

Compound 3, inhibition constant: 389 nM
Beside the measured number, compound 3's estimate is 3.1-fold (0.49 log units) above it; measured number outside the range, below it.
By their numbers in this assay, from the lowest: compounds 3 and 2 (each within the scatter of the next); then compound 1.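

In this assay, putting a methyl in place of the hydroxy on this aromatic carbon, para to the methanesulfonamido group, gives a 1.8-fold lower number from compound 2 to compound 3 (0.26 log units; within the scatter). Among the compounds shown here, this is the first direct comparison at this position, and it shows that the two groups cannot be told apart here: the hydroxy has a hydrogen-bond donor and a hydrogen-bond acceptor, the methyl has neither, and yet the step does not leave the usual scatter, so this pair gives no sign that either feature matters for this read-out. Nothing measured here explains this outcome.

From the compounds shown here alone, with only these two small groups compared at this position, it remains open how a methoxy, an amine, a chlorine or a longer chain such as ethyl would read in this assay. Going by these compounds, compound 1 differs from compound 2 and from compound 3 in more than one place, so it also remains open whether the same swap would give a similar result alongside the propanesulfonamido group.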